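Compound 1 to compound 4: one group changes

The source may hold more compounds than are shown below. What is called first, only, known or untested is meant among the compounds shown, and "the series" means these compounds.

Measured in a functional assay on A549 cells (Homo sapiens) for antiproliferative activity, read by spectrophotometry, with a stated time of 2 days; on this read-out higher numbers stand for weaker inhibition of growth and lower numbers for stronger inhibition of growth:
compound 1 `COc1ccc(C(F)(F)F)cc1Nc1ncc(C(F)(F)F)c(N2Cc3cccc(N(C)S(C)(=O)=O)c3C2)n1`: > 30000 nM, a limit
compound 2 `COc1cc(N2CCN(C(C)=O)CC2)ccc1Nc1ncc(C(F)(F)F)c(N2Cc3cccc(N(C)S(C)(=O)=O)c3C2)n1`: 3300 nM
compound 3 `CN(c1cccc2c1CN(c1nc(Nc3cc(C(F)(F)F)cc(C(F)(F)F)c3)ncc1C(F)(F)F)C2)S(C)(=O)=O`: > 30000 nM, a limit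

A result written with a sign is a limit of the assay and not a number. Compound 1 gives only such a limit, > 30000 nM. It stands at the limit of > 30000 nM in this assay, at which 2 of the 3 values shown sit. Among the three, only compound 2 gives an actual number, 3300 nM.

The compound still to be measured is compound 4 `COc1cc(Nc2ncc(C(F)(F)F)c(N3Cc4cccc(N(C)S(C)(=O)=O)c4C3)n2)cc(OC)c1`. It keeps the core of compound 1 and changes one group: 3,5-dimethoxyphenyl in place of 2-methoxy-5-(trifluoromethyl)phenyl on a nitrogen on an aromatic ring. In words, this is 3,5-dimethoxyphenyl in place of 2-methoxy-5-(trifluoromethyl)phenyl on a nitrogen on an aromatic ring.

Among the compounds with values here, no measured pair isolates this change, so any forecast rests on thin evidence. Compound 1 and compound 3 both carry trifluoromethyl in this group, and both stop at the limit. Compound 4 carries none there, and compound 2, which also has none, reaches 3300 nM. A modest shift towards stronger inhibition in this assay is therefore expected, although another limit is quite possible. The expected step is an at least 1.5-fold lower number from compound 1 to compound 4 (0.17 log units; that floor lies within the scatter). For compound 4 the estimate is 20000 nM, with an expected range from 7000 nM to 30000 nM.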

Compound 4, concentration for 50% growth inhibition: 24800 nM
For compound 4 the middle estimate is 1.2-fold (0.09 log units) below the measured one; the range from low to high includes it.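

In this assay, 3,5-dimethoxyphenyl in place of 2-methoxy-5-(trifluoromethyl)phenyl on a nitrogen on an aromatic ring gives an at least 1.2-fold lower number from compound 1 to compound 4 (0.08 log units; that floor lies within the scatter). As far as these compounds go, compound 1 gives only a limit, so this step is a floor and its true size stays unknown: the limit of > 30000 nM in this assay, at which 2 of the 4 values shown sit. What is new is that a group without trifluoromethyl at this position can still leave the number high, since compound 4 gives 24800 nM while compound 2, also free of trifluoromethyl, gives 3300 nM, so the absence of trifluoromethyl does not by itself bring a compound to the value of compound 2.

The compounds shown leave open what sets compound 2 apart, whether its acetylpiperazine, its single methoxy or the two together, as no compound here carries one of these without the other. They also leave open how the number would respond to a phenyl group carrying a morpholine, a free amine or a carboxylic acid at this position on the shared core.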